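The source may hold more compounds than are shown below. What is called first, only, known or untested is meant among the compounds shown, and "the series" means these compounds.

Within the data shown here, compound 3 `CCCCCCCCCCc1cn(C[C@H](O)[C@H]2OC(=O)C(OCc3ccccc3)=C2OCc2ccccc2)nn1` gives 40300 nM in a functional assay on CFPAC-1 cells (Homo sapiens) for antiproliferative activity, read by MTT assay, with a stated time of 72 h (a lower number here means a stronger inhibitor, a higher number a weaker inhibitor), and is the only compound of the series with a plain number there. Compound 1 `O=C1O/C(=C\Cn2cc(-c3cc(F)cc(F)c3)nn2)C(OCc2ccccc2)=C1OCc1ccccc1` is recorded as "not active" (no number reported) in this assay and carries no number. Compound 2 `O=C1O/C(=C\Cn2cc(-c3cc(C(F)(F)F)cc(C(F)(F)F)c3)nn2)C(OCc2ccccc2)=C1OCc1ccccc1` reads > 100000 nM in this assay and this is a limit of the assay, not a number.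

Compound 4 `C[Si](C)(C)c1cn(C[C@H](O)[C@H]2OC(=O)C(OCc3ccccc3)=C2OCc2ccccc2)nn1` has not yet been measured. It differs from compound 3 by a single change a group of 4 heavy atoms (3 carbon, 1 silicon; no ring) in place of a group of 10 heavy atoms (10 carbon; no ring), on an aromatic carbon where the decyl group leaves the aromatic carbon of the five-membered aromatic ring with 3 nitrogen. Among the measured compounds shown here, the series holds no measured step for this change, so the expectation rests on compound 3 at 40300 nM alone and is loose. A small shift toward weaker inhibition is expected a 1.5-fold higher number from compound 3 to compound 4 (0.17 log units; within the scatter) and a report as a limit only remains a real possibility. In this assay the estimate for compound 4 is 60000 nM with an expected range from 15000 nM to 100000 nM.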

Compound 4, half-maximal inhibitory concentration: 52600 nM
Beside the measured number, compound 4's estimate is 1.1-fold (0.06 log units) above it; the measured number falls inside the stated range.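

In this assay, among these compounds, this is the first measured step at this aromatic carbon of the five-membered aromatic ring with 3 nitrogen: a 1.3-fold higher number from compound 3 to compound 4 (0.12 log units; within the scatter) comes with a group of 4 heavy atoms (3 carbon, 1 silicon) in place of decyl. A measurable value at this position therefore does not depend on the decyl chain, since the much smaller group without a ring leaves the number within the scatter. Compound 4 also reads as a plain number, while compound 2 stands at a limit of the assay, not a number: the limit of > 100000 nM in this assay, at which 1 of the 4 values shown sits.

Going by these compounds, whether any group at this carbon moves the number beyond the scatter remains open, for example an amine, a carboxylic acid or a longer chain. With a single step at this position, no trend with chain length can be read.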